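An aromatic amide group at the assay limit

The compounds below may be only part of what the source reports. "The series", "measured", "known", "first", "only" and "open" are said of these compounds alone.

In an ADME assay on HepG2 cells (Homo sapiens) for inhibition, with a stated time of 48 h (a higher number here means that more compound is needed for the effect, a lower number that less compound is needed), compound 1 (`CC(C(=O)N1CCCCC1)N1CCN(S(=O)(=O)c2ccc(C(C)(C)C)cc2)CC1`) reads > 40000 nM as a limit and not a number. Compound 2 (`CC(C(=O)N1CCC2(CC1)CC2)N1CCN(S(=O)(=O)c2ccc(C(C)(C)C)cc2)CC1`) reads > 40000 nM as a limit as well. Compound 2 thus stands at the limit of > 40000 nM in this assay, at which 2 of the 2 values shown sit, and has no number of its own.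

Compound 3 (`CC(C(=O)N1CCc2ccccc21)N1CCN(S(=O)(=O)c2ccc(C(C)(C)C)cc2)CC1`) has not yet been measured. The change is a group of 9 heavy atoms (8 carbon, 1 nitrogen; one five-membered non-aromatic ring with 1 hetero atom, one six-membered aromatic ring of carbon only) in place of a group of 8 heavy atoms (7 carbon, 1 nitrogen; one three-membered non-aromatic ring of carbon only, one six-membered non-aromatic ring with 1 hetero atom), on a carbonyl carbon and it brings in 2,3-dihydro-1H-indol-1-yl on a carbonyl carbon. Going by the values given here, the one measured step on this carbonyl carbon is a step that the two limits leave unreadable from compound 1 to compound 2 and gives no size to carry over. In this assay the expected step is a number no higher from compound 2 to compound 3 (the limit leaves the size open) with nothing beyond the scatter foreseen and no direction favoured. For compound 3 the estimate is 40000 nM with an expected range from 15000 nM to 100000 nM and another reading at the limit is expected as the likeliest result.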

Compound 3, half-maximal effective concentration: > 40000 nM
Compound 3: a limit, no number (the forecaster's own chance of this, stated with the estimate: 70%); the middle value lies on the limit itself.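

Compound 3 reads as a limit and not a number in this assay, so its steps from compound 1 and from compound 2 cannot be read. The compounds shown leave open whether the group on the carbonyl carbon changes the read-out at all, because all of them sit at the same point: the limit of > 40000 nM in this assay, at which 3 of the 3 values shown sit.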